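Hydroxymethyl to hydrogen: what compound 4 should show

A few compounds are considered here, and "the series" means these few. Any claim that something is new, unique, unknown or untested is made for them only; others in the source may bear on it.

Values in a functional assay on HeLa cells (Homo sapiens) for inhibition; a higher number here means a weaker inhibitor, a lower number a stronger inhibitor:
- compound 1 `CCCCCCCCCCCCCCCCCCOC[C@H](COP(=O)(O)O[C@H]1[C@@H](O)[C@@H](O)[C@H](O)C[C@H]1O)OC`: 7000 nM
- compound 2 `CCCCCCCCCCCCCCCCCCOC[C@H](COP(=O)(O)O[C@@H]1[C@H](O)[C@@H](CO)[C@@H](O)[C@H](O)[C@@H]1O)OC`: 7500 nM
- compound 3 `CCCCCCCCCCCCCCCCCCOC[C@H](COC(=O)O[C@@H]1[C@H](O)[C@@H](CO)[C@@H](O)[C@H](O)[C@@H]1O)OC`: > 20000 nM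

Compound 3 is reported only as a limit, > 20000 nM. All that is known of its place is the limit of > 20000 nM in this assay, at which 1 of the 3 values shown sits. Compound 4 `CCCCCCCCCCCCCCCCCCOC[C@H](COC(=O)O[C@H]1[C@@H](O)[C@@H](O)[C@H](O)C[C@H]1O)OC` is compound 3 with hydrogen in place of hydroxymethyl on a saturated ring carbon. Among the compounds with values here, one measured step bears on this change, the same exchange in reverse, hydroxymethyl in place of hydrogen on a saturated ring carbon: a 1.1-fold higher number from compound 1 to compound 2 (0.03 log units; within the scatter). That step lies in a different setting, since compound 1 and compound 2 differ from compound 3 and compound 4 elsewhere in the structure. On this single step, no change beyond the scatter is expected in this assay, in either direction. The expected step is a step that the limit leaves unreadable from compound 3 to compound 4. Compound 4 may well also be reported only as a limit. As a number, compound 4 is estimated at 25000 nM, with an expected range from 12000 nM to 60000 nM.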

Compound 4, half-maximal inhibitory concentration: 30000 nM
Beside the measured number, compound 4's estimate is 1.2-fold (0.08 log units) below it; the range from low to high includes it.
By their numbers in this assay, from the lowest: compounds 1 and 2 (each within the scatter of the next); then compound 4.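

No new step can be read between compound 3 and compound 4 in this assay, because compound 3 stands only as a limit: the limit of > 20000 nM in this assay, at which 1 of the 4 values shown sits. The compounds shown leave open whether hydrogen in place of hydroxymethyl on a saturated ring carbon changes the number at all in this pair.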